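The compounds below may be only part of what the source reports. "The series", "measured", "known", "first", "only" and "open" are said of these compounds alone.

Measured in a functional assay on MDA-MB-436 cells (Homo sapiens) for antiproliferative activity, read by MTT assay, with a stated time of 48 h; on this read-out higher numbers stand for weaker inhibition and lower numbers for stronger inhibition:
- compound 1 `C=CS(=O)(=O)N1CCN(c2ncnc3sc(-c4ccccc4)cc23)CC1`: 21100 nM
- compound 2 `C=CS(=O)(=O)N1CCN(c2ccn3ncc(-c4ccccc4)c3n2)CC1`: 19500 nM

Compound 1 at 21100 nM and compound 2 at 19500 nM lie within the usual scatter of each other, so the numbers do not separate them. Compound 3 `C=CS(=O)(=O)N1CCN(c2ncnc3sc(-c4ccc(N5CCN(C)CC5)cc4)cc23)CC1` keeps the core of compound 1 and carries 4-methylpiperazin-1-yl in place of hydrogen on an aromatic carbon, on the six-membered aromatic ring of carbon only, para to a large group: 4-methylpiperazin-1-yl in place of hydrogen on an aromatic carbon. For the measured compounds named here, no measured pair shows what such a change does in this assay, so this expectation is loose. A moderate move towards a lower number, meaning stronger inhibition, is expected, as an estimated 3.0-fold lower number from compound 1 to compound 3 (0.48 log units; beyond the scatter). Compound 3 is estimated at 7000 nM, with an expected range of 1800 nM to 26000 nM.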

Compound 3, half-maximal inhibitory concentration: 8760 nM
Estimate against measurement, compound 3: 1.3-fold (0.10 log units) below; the measured number falls inside the stated range.
By their numbers in this assay, from the lowest: compound 3; then compounds 2 and 1 (each within the scatter of the next).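

In this assay, 4-methylpiperazin-1-yl in place of hydrogen on this aromatic carbon gives a 2.4-fold lower number from compound 1 to compound 3 (0.38 log units; beyond the scatter) and this modest step lies beyond the scatter. This position therefore takes a fairly large ring-bearing group with a move towards stronger inhibition, the first change shown that separates two compounds. Nothing available explains the move.

Still open, as far as these compounds go, is whether a smaller amine such as dimethylamino, or a morpholine ring, would act in the same way at this position. Also open, from the compounds shown here alone, is whether 4-methylpiperazin-1-yl would have a similar effect on compound 2.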